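Acetamido analog in the cytotoxicity series

A few compounds are considered here, and "the series" means these few. Any claim that something is new, unique, unknown or untested is made for them only; others in the source may bear on it.

Compound 1: `Cc1cn([C@@H]2O[C@H](CO[Si](C)(C)C(C)(C)C)[C@@]3(OS(=O)(=O)C=C3NCC(=O)O)[C@H]2O[Si](C)(C)C(C)(C)C)c(=O)n(C)c1=O` — 300000 nM
Compound 2: `Cc1cn([C@@H]2O[C@H](CO[Si](C)(C)C(C)(C)C)[C@@]3(OS(=O)(=O)C=C3NCC(=O)C(=O)N3CCC3)[C@H]2O[Si](C)(C)C(C)(C)C)c(=O)n(C)c1=O` — 65000 nM

Among the compounds with values here, in a functional assay on HEL cells (Homo sapiens) for cytotoxicity, read by microscopy (on this read-out higher numbers stand for lower toxicity in this test and lower numbers for higher toxicity in this test), compound 2 gives the lowest of the two numbers, with compound 1 as its only neighbour. Within the data shown here, the one measured step, a 4.6-fold lower number from compound 1 to compound 2 (0.66 log units; beyond the scatter), changed the end of the chain rather than the chain itself. Compound 3, `CC(=O)NC1=CS(=O)(=O)O[C@@]12[C@@H](CO[Si](C)(C)C(C)(C)C)O[C@@H](n1cc(C)c(=O)n(C)c1=O)[C@@H]2O[Si](C)(C)C(C)(C)C`, differs from compound 2 by acetyl in place of (((azetidin-1-yl)carbonyl)carbonyl)methyl on an amine nitrogen. Among the measured compounds shown here, no measured step removes this chain, so that step gives only a loose guide. A move back toward compound 1 is expected, and a 2.3-fold higher number from compound 2 to compound 3 (0.36 log units; beyond the scatter) is estimated. For compound 3 the expected value is 150000 nM, within 40000 nM to 400000 nM.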

Compound 3, minimum cytotoxic concentration: >= 80000 nM
Compound 3: a limit, no number; the forecaster's own chance of this, stated with the estimate: 25%; the middle value is on the limit's open side.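

In this assay, compound 3 gives a limit and not a number: the limit of >= 80000 nM in this assay, at which 1 of the 3 values shown sits.

At the amine nitrogen, acetyl in place of (((azetidin-1-yl)carbonyl)carbonyl)methyl gives an at least 1.2-fold higher number from compound 2 to compound 3 (0.09 log units; that floor lies within the scatter), so this change shows no separation between the two groups beyond the scatter. The step from compound 1 to compound 3 cannot be read, which leaves acetyl and carboxymethyl unordered on this nitrogen.

Going by these compounds, the actual value for compound 3 remains open. So does the effect of a plain amine or a longer propanoyl chain at this nitrogen.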